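This account rests on a few compounds, and the source may have more. Where it says the series, first, only, none or still open, it means among the compounds named here.

Measured compounds:
- compound 1, `CC(=O)O[C@@H]1[C@@H](OC(C)=O)[C@H](S[C@@H]2C/C(=N/C(N)=S)[C@@H]3OC[C@H]2O3)OC[C@@H]1OC(C)=O`: in a functional assay on M059J cells (Homo sapiens) for cytotoxicity, read by CCK-8 assay, with a stated time of 72 h (on this read-out lower numbers stand for stronger inhibition and higher numbers for weaker inhibition), compound 1 gives > 1000000 nM, which is a limit of the assay and not a number
- compound 2, `CC(=O)OC[C@H]1O[C@@H](S[C@@H]2C/C(=N/C(N)=S)[C@@H]3OC[C@H]2O3)[C@H](OC(C)=O)[C@@H](OC(C)=O)[C@H]1OC(C)=O`: compound 2 gives > 1000000 nM, again a limit of the assay and not a number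

The step from compound 1 to compound 2, acetoxymethyl in place of hydrogen on a saturated ring carbon, reads a step that the two limits leave unreadable from compound 1 to compound 2. Going by the values given here, compound 2 therefore stands only at a limit in this assay; the point the limit of > 1000000 nM in this assay, at which 2 of the 2 values shown sit, covers every value shown for the series so far.

Compound 3, `CC(=O)OC[C@H]1O[C@@H](S[C@@H]2C/C(=N/C(N)=S)[C@@H]3OC[C@H]2O3)[C@H](OC(C)=O)[C@@H](OC(C)=O)[C@@H]1OC(C)=O`, differs from compound 2 in this way: the two compounds have the same atoms and bonds and differ only in configuration as drawn: 1 of 9 stereo elements differ; a stereocentre at a saturated ring carbon is drawn S in compound 2 and R in compound 3. Among the compounds with values here, no measured step concerns a change of configuration, and the single measured step is itself unreadable, so nothing gives the size or direction of the move in this assay. With both measured values sitting at the limit, no step beyond the scatter is expected, and the step from compound 2 to compound 3 is estimated as a number no higher from compound 2 to compound 3 (the limit leaves the size open). Compound 3 is expected at 1000000 nM, within a range from 300000 nM to 3000000 nM, most likely reported once more only as a limit.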

Compound 3, half-maximal inhibitory concentration: > 1000000 nM
Compound 3 gave a limit, no number (the forecaster's own chance of this, stated with the estimate: 85%); the middle value lies on the limit itself.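

In this assay compound 3 gives > 1000000 nM, a limit of the assay and not a number. Going by these compounds alone, no step between compound 2 and compound 3 can be read from this result. What remains open is whether the change of configuration or any other change in these compounds alters the activity in this assay at all: the limit of > 1000000 nM in this assay, at which 3 of the 3 values shown sit.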